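The source may report more compounds than this note shows. Statements on the series, on what has been measured and on what is new or still open speak of the compounds shown alone.

In an ADME assay on S9 fraction from liver (Homo sapiens) for metabolic stability, with a stated time of 1 h (a lower number here means that less of the compound is left, a higher number that more of the compound is left), compound 1 (`N#Cc1cnc(NCc2cnccc2C(F)(F)F)cc1N[C@H]1C[C@H](O)C1`) stands at 96% and compound 2 (`CN(C)C(=O)[C@H]1CC[C@@H](Nc2cc(NCc3cnccc3C(F)(F)F)ncc2C#N)CC1`) at 48% while compound 3 (`N#Cc1cnc(NCc2cncnc2-c2ccccc2)cc1N[C@H]1CC[C@@H](O)CC1`) gives 42% as its reading. That places compound 3 level with compound 2, within the scatter, and far under compound 1, beyond the scatter. Compound 4 (`N#Cc1cnc(NCc2cncnc2OCC(F)F)cc1N[C@H]1CC[C@@H](O)CC1`) differs from compound 3 by a single change (2,2-difluoroethoxy in place of phenyl on an aromatic carbon): 2,2-difluoroethoxy in place of phenyl on an aromatic carbon. Among the compounds with values here, no measured pair shows this exchange, so any expectation remains loose. In this assay a modest rise is expected, and the estimated step of a number 14 percentage points higher from compound 3 to compound 4 (beyond the scatter) may only just clear the scatter. For compound 4 the estimated value is 56% with 35% to 78% as the expected range.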

Compound 4, percent of the compound remaining: 87%
Compound 4: the middle estimate sits 31 percentage points below what was measured; measured number above the stated range.
By their numbers in this assay, from the lowest: compounds 3 and 2 (each within the scatter of the next); then compounds 4 and 1 (each within the scatter of the next).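

In this assay, placing 2,2-difluoroethoxy in place of phenyl on this aromatic carbon, next to the ring nitrogen, gives a large step, a number 45 percentage points higher from compound 3 to compound 4 (beyond the scatter) on an otherwise unchanged structure. Within the data shown here, this is the first direct sign that the group at this position bears on the reading. Nothing at hand explains the step.

This single pair cannot separate the roles of the oxygen, the fluorines and the loss of the phenyl ring. On these data alone, whether a plain ethoxy, a methoxy or an amine here would read the same remains open.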